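Exchanging One Polar Amino Group for Another on a Carbonyl Carbon

The source may hold more compounds than are shown below. What is called first, only, known or untested is meant among the compounds shown, and "the series" means these compounds.

Measured compounds:
compound 1, `COc1cc(NC(C)CCCNC(=O)NNC(=O)N(CCO)CCO)c2ncccc2c1`, > 250000 nM
compound 2, `COc1cc(NC(C)CCCNC(=O)N(C)C(c2ccccc2)c2ccccc2)c2ncccc2c1`, 21000 nM
compound 3, `COc1cc(NC(C)CCCNC(=O)NNC(=O)N(C)C(c2ccccc2)c2ccccc2)c2ncccc2c1`, 18000 nM

Three compounds sharing the same core have been run in a functional assay on MIA PaCa-2 cells (Homo sapiens) for inhibition, read by MTT assay, with a stated time of 4 days; on this read-out higher numbers stand for weaker inhibition and lower numbers for stronger inhibition. Compound 1 reaches only the limit of this assay, reported as > 250000 nM, so for compound 1 there is a bound and no number. Within the data shown here, it is the single compound at this bound: the limit of > 250000 nM in this assay, at which 1 of the 3 values shown sits. The two other compounds do give numbers: compound 2 shows 21000 nM in this assay, and compound 3 shows 18000 nM, the two values sitting within the usual scatter of each other.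

The account now follows compound 1 to compound 4, `COc1cc(NC(C)CCCNC(=O)NNC(=O)NC(CO)(CO)CO)c2ncccc2c1`, which is not yet measured in this assay. The change is (2-hydroxy-1,1-bis(hydroxymethyl)ethyl)amino in place of bis(2-hydroxyethyl)amino on a carbonyl carbon. Both the leaving group and the entering group are small, uncharged and hydroxyl-bearing, with no ring in either. Among the measured compounds shown here, no measured pair within this set isolates such a change, so no measured step can be pointed to. Given that compound 1 sits at the limit, the step from compound 1 to compound 4 is expected to be none beyond the scatter, a number no higher from compound 1 to compound 4 (the limit leaves the size open). Compound 4 is therefore estimated at 250000 nM in this assay, within a range from 80000 nM to 800000 nM, and it is expected that compound 4 will most likely again return only a limit rather than a number.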

Compound 4, half-maximal inhibitory concentration: > 250000 nM
Compound 4 ended at the assay's limit (the forecaster's own chance of this, stated with the estimate: 75%); the middle value lies on the limit itself.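

Compound 1 and compound 4 both return only a limit in this assay, so no step between them can be read: the limit of > 250000 nM in this assay, at which 2 of the 4 values shown sit.

The compounds shown leave open whether (2-hydroxy-1,1-bis(hydroxymethyl)ethyl)amino in place of bis(2-hydroxyethyl)amino changes inhibition at all.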